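The compounds below may be only part of what the source reports. "The series", "measured", "known", "first", "only" and "open" are said of these compounds alone.

Compound 1, `CC(C)=CC(=O)NC(=N)N`, gives 92800 nM in a functional assay on B16-F10 cells (Mus musculus) for inhibition, read by MTT assay, with a stated time of 72 h; on this read-out lower numbers stand for stronger inhibition of growth and higher numbers for weaker inhibition of growth. Compound 2, `C=C1CCCC(C)(C)[C@@H]1CC/C(C)=C/C(=O)NC(=N)NC(=O)C=C(C)C`, gives 9600 nM. Compound 3, `CC(C)=CCC/C(C)=C/CC/C(C)=C/C(=O)NC(=N)NC(=O)C=C(C)C`, gives 7500 nM. Compound 3 therefore stands together with compound 2, the two numbers lying within the scatter of each other, while the gap from compound 3 to compound 1 is well beyond it. Compound 4, `CC(C)=CCC/C(C)=C/CC/C(C)=C/C(=O)NC(=N)NC(=O)/C=C(\C)CCC=C(C)C`, carries the change (3-methylbut-2-en-1-yl in place of hydrogen on a saturated chain carbon bound to a double-bonded chain carbon). Since the longer chains of compounds 2 and 3 go with markedly lower numbers than compound 1, a further chain is expected to shift the number downward only slightly, and the step of a 1.7-fold lower number from compound 3 to compound 4 (0.22 log units; within the scatter) is estimated to be small, perhaps within the scatter. For compound 4 the expected value is 4500 nM, in a range from 1500 nM to 13000 nM.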

Compound 4, concentration for 50% growth inhibition: 18900 nM
The estimate for compound 4 lay 4.2-fold (0.62 log units) below the measured number; measured number above the stated range.
By their numbers in this assay, from the lowest: compounds 3, 2 and 4 (each within the scatter of the next, the first and the last beyond it); then compound 1.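

In this assay, 3-methylbut-2-en-1-yl in place of hydrogen on a saturated chain carbon bound to a double-bonded chain carbon gives a 2.5-fold higher number from compound 3 to compound 4 (0.40 log units; beyond the scatter) and thus a modest loss of growth inhibition, beyond the scatter. For the compounds shown here, the earlier compounds offered no pair differing in one place, so this is the first direct reading of a change at this position. No evidence given here accounts for the step. Going by these compounds, it remains open whether ethyl, an amine or a carboxylic acid at this carbon would move the number the same way.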